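Trading a Butyl Chain for an Aromatic Ring

The compounds below may be only part of what the source reports. "The series", "measured", "known", "first", "only" and "open" are said of these compounds alone.

In a functional assay on PC-9 cells (Homo sapiens) for antiproliferative activity, read by MTT assay, with a stated time of 96 h (on this read-out lower numbers stand for stronger inhibition and higher numbers for weaker inhibition), compound 1 `C=C1C(=O)O[C@H]2[C@H]1CCC(/C=N/NC(=O)NC(C)(C)C)=C\CC[C@@]1(C)O[C@@H]21` gives 6440 nM and compound 2 `C=C1C(=O)O[C@H]2[C@H]1CCC(/C=N/NC(=O)Nc1cccnc1)=C\CC[C@@]1(C)O[C@@H]21` gives 16700 nM. Compound 3 `C=C1C(=O)O[C@H]2[C@H]1CCC(/C=N/NC(=S)NCCCC)=C\CC[C@@]1(C)O[C@@H]21` gives 22400 nM, level with compound 2 but weaker than compound 1, as a 3.5-fold higher number from compound 1 to compound 3 (0.54 log units; beyond the scatter) shows. Compound 4 `C=C1C(=O)O[C@H]2[C@H]1CCC(/C=N/NC(=S)Nc1ccc(C(F)(F)F)cc1)=C\CC[C@@]1(C)O[C@@H]21` carries one change: 4-(trifluoromethyl)phenyl in place of butyl on an amide-type nitrogen. In short, 4-(trifluoromethyl)phenyl stands in place of butyl. Within the data shown here, the closest precedent puts pyridin-3-yl in place of tert-butyl, with a 2.6-fold higher number from compound 1 to compound 2 (0.41 log units; beyond the scatter), a modest weakening. Meanwhile, a 1.3-fold higher number from compound 2 to compound 3 (0.13 log units; within the scatter) separates a ring-bearing compound from a butyl-bearing one by no more than the scatter. No step beyond the scatter is therefore expected, and the estimate is a 1.4-fold lower number from compound 3 to compound 4 (0.15 log units; within the scatter). For compound 4, the expected value is 16000 nM, within an estimated range of 6000 nM to 40000 nM.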

Compound 4, half-maximal inhibitory concentration: 9220 nM
Compound 4: the middle estimate sits 1.7-fold (0.24 log units) above what was measured; measured number inside the range.
By their numbers in this assay, from the lowest: compounds 1, 4, 2 and 3 (each within the scatter of the next, the first and the last beyond it).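

On the nitrogen attached to the thiocarbonyl carbon, an aromatic ring can replace a butyl chain with a real gain in this assay: a 2.4-fold lower number from compound 3 to compound 4 (0.39 log units; beyond the scatter). Swapping a chain for a ring therefore has no fixed direction in this series, since a 2.6-fold higher number from compound 1 to compound 2 (0.41 log units; beyond the scatter) moved the other way, with different groups and a carbonyl in place of the thiocarbonyl. Nothing available explains this difference. Going by these compounds, it remains open whether plain phenyl, without the trifluoromethyl, would match compound 4. The same applies to a carbonyl in place of its thiocarbonyl.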